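Compound 3 to compound 4: an isobutyl exchange

This account rests on a few compounds, and the source may have more. Where it says the series, first, only, none or still open, it means among the compounds named here.

Of the compounds shown here, three sharing one core have been read in an ADME assay on Huh-7 cells (Homo sapiens) for cytotoxicity, with a stated time of 72 h; on this read-out higher numbers stand for lower toxicity in this test and lower numbers for higher toxicity in this test: compound 1 `CC(C)CCn1nc(-c2ccn(C)c2)c(O)c(C2=NS(=O)(=O)c3cc(NS(C)(=O)=O)ccc3N2)c1=O`, compound 2 `CC(C)=Cc1nn(CCC(C)C)c(=O)c(C2=NS(=O)(=O)c3cc(NS(C)(=O)=O)ccc3N2)c1O` and compound 3 `C/C(=C\c1nn(CCC(C)C)c(=O)c(C2=NS(=O)(=O)c3cc(NS(C)(=O)=O)ccc3N2)c1O)C(F)(F)F`. Compound 1 gives > 1000 nM, which is a limit of the assay. Compound 2 gives > 1000 nM, also a limit. Compound 3 gives > 33000 nM, again a limit and not a number, so this is where compound 3 stands. Across the set, the values sit at the limit of > 1000 nM in this assay, at which 2 of the 3 values shown sit, or at the limit of > 33000 nM in this assay, at which 1 of the 3 values shown sits.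

Compound 4 `CC(C)CCn1nc(CC(C)C)c(O)c(C2=NS(=O)(=O)c3cc(NS(C)(=O)=O)ccc3N2)c1=O` differs from compound 3 as follows: isobutyl in place of 2-(trifluoromethyl)prop-1-en-1-yl on an aromatic carbon. In words, this is isobutyl in place of 2-(trifluoromethyl)prop-1-en-1-yl on an aromatic carbon next to the ring nitrogen.

The same carbon changes in all three measured steps. The closest is a step that the two limits leave unreadable from compound 2 to compound 3, followed by a step that the two limits leave unreadable from compound 1 to compound 2 and a step that the two limits leave unreadable from compound 1 to compound 3. Within the data shown here, none of them supplies a size, so no measured step can be carried over to the new exchange, and no direction is supported in this assay. The expected result is no change beyond the scatter, stated as a number no higher from compound 3 to compound 4 (the limit leaves the size open). For compound 4 the estimate is 33000 nM, with an expected range from 5000 nM to 100000 nM. A report as a limit is also expected.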

Compound 4, half-maximal cytotoxic concentration: > 1000 nM
Compound 4: no number, only a limit; the forecaster's own chance of this, stated with the estimate: 85%; the middle value does not contradict the limit.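

In this assay compound 4 gives > 1000 nM, a limit of the assay and not a number. The steps to compound 4 from compound 1, compound 2 and compound 3 all join two limits and cannot be read. The compounds shown leave open whether any exchange on this aromatic carbon shifts the read-out, and by how much.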